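Removing a Methoxy Group from a Urotensin-2 Receptor Agonist

This account rests on a few compounds, and the source may have more. Where it says the series, first, only, none or still open, it means among the compounds named here.

Three measured compounds share a core bearing a dimethylamino chain and an amide, and each was tested in a functional assay on NIH3T3 cells for agonist activity at Urotensin-2 receptor (Homo sapiens), with a stated time of 5 days; on this read-out lower numbers stand for an effect already at smaller amounts and higher numbers for an effect only at larger amounts of compound. Compound 1 `Cc1ccc(C(CCN(C)C)NC(=O)C#Cc2ccccc2)cc1` gives 3090 nM in this assay. Compound 2 `COc1ccc(CCC(=O)NC(CCN(C)C)c2ccc3ccccc3c2)cc1` gives 1410 nM in this assay, and compound 3 `CN(C)CCC(NC(=O)/C=C/c1ccccc1)c1ccc(Cl)cc1` gives 427 nM. Among these three numbers, compound 2 stands second highest: the gap to compound 1, which sits above it, and the larger gap to compound 3, which sits below it, both lie beyond the usual scatter of this kind of measurement.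

Compound 4 `CN(C)CCC(NC(=O)CCc1ccccc1)c1ccc2ccccc2c1` differs from compound 2 in one place: hydrogen in place of methoxy on an aromatic carbon. Among the compounds with values here, no pair of measured compounds shows this change on its own, so its effect here is unknown. A small step is expected, if any, and a drift toward a higher number seems somewhat more likely than toward a lower one. Compound 4 is therefore expected to give about 2000 nM in this assay, with a plausible range from 700 nM to 6000 nM. This estimate means an expected step of a 1.4-fold higher number from compound 2 to compound 4 (0.15 log units; within the scatter), close to the scatter.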

Compound 4, half-maximal effective concentration: 603 nM
Compound 4: the middle estimate sits 3.3-fold (0.52 log units) above what was measured, outside the stated range (below it).
By their numbers in this assay, from the lowest: compounds 3 and 4 (each within the scatter of the next); then compound 2; then compound 1.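

In this assay replacing the methoxy group with hydrogen on the 4-methoxyphenyl ring brings a 2.3-fold lower number from compound 2 to compound 4 (0.37 log units; beyond the scatter), a modest change but larger than the usual scatter. The methoxy group at this position is therefore not needed for agonist activity in this series, and the plain phenyl version gives an effect at smaller amounts of compound. This is the first view of the change on its own, since the earlier compounds differ from one another in more than one place, but no measurement shown here explains the step.

Going by these compounds, it remains open how other groups at this same position, such as a fluorine, a hydroxyl or an amine, would compare with hydrogen and methoxy. It is also unclear whether removing a methoxy group would give a similar step on a different amide side chain.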